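A few compounds are considered here, and "the series" means these few. Any claim that something is new, unique, unknown or untested is made for them only; others in the source may bear on it.

Of the compounds shown here, two have been measured in a functional assay on SJ-G2 cells (Homo sapiens) for inhibition, read by MTT assay, with a stated time of 72 h; on this read-out lower numbers stand for stronger inhibition of growth and higher numbers for weaker inhibition of growth. Compound 1, `N#C/C(=C\c1ccc([N+](=O)[O-])cc1)C(=O)c1c[nH]c2ccccc12`, gives 37000 nM in this assay. Compound 2, `COc1ccc(CNC(=O)/C(C#N)=C/c2ccc(C)o2)cc1`, gives 75000 nM in this assay, which is the highest of the two numbers; the nearest number, that of compound 1, is lower, and the gap between the two lies beyond the usual scatter of repeated measurements. Going by the values given here, no single-point step between measured compounds is available, so the record gives no direct guide to how a change on the furan ring plays out.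

Compound 3, `COc1ccc(CNC(=O)/C(C#N)=C/c2cc(Br)co2)cc1`, differs from compound 2 in one place: 4-bromofuran-2-yl in place of 5-methylfuran-2-yl on a double-bonded chain carbon bound to a double-bonded chain carbon. Among the compounds with values here, the measured pair offers no precedent for a change of this kind, and the swap exchanges one substituted furan for another of the same size. The step in this assay from compound 2 to compound 3 is therefore expected to be small, a 1.3-fold lower number from compound 2 to compound 3 (0.10 log units; within the scatter), with no direction that can be stated with confidence beyond the scatter. On that basis compound 3 is estimated to give 60000 nM in this assay, within a range from 20000 nM to 150000 nM.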

Compound 3, concentration for 50% growth inhibition: 23000 nM
Compound 3: the middle estimate sits 2.6-fold (0.42 log units) above what was measured; low and high end bracket the measured number.
By their numbers in this assay, from the lowest: compounds 3 and 1 (each within the scatter of the next); then compound 2.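

The exchange of 5-methylfuran-2-yl for 4-bromofuran-2-yl on a double-bonded chain carbon bound to a double-bonded chain carbon provides the only single-place step among these compounds, and in this assay it gives a 3.3-fold lower number from compound 2 to compound 3 (0.51 log units; beyond the scatter) and so lies beyond the scatter, though it is modest in size. This shows that the result at this position is not indifferent to which substituted furan it carries, even though the two groups match in heavy-atom count, ring type, hydrogen-bond donors, hydrogen-bond acceptors and charge. No measurement at hand offers an explanation for the step.

The compounds shown leave open whether the bromine itself or its location on the furan goes with the lower number, as the single step changes both the substituent and its ring location. From the compounds shown here alone, how 5-bromofuran-2-yl or 4-methylfuran-2-yl would read here remains open, as does whether a chlorine atom or an amine on the furan would move the number in the same direction.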